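The source may report more compounds than this note shows. Statements on the series, on what has been measured and on what is new or still open speak of the compounds shown alone.

Working notes on a small set of macrocyclic depsipeptides, all read in a functional assay on MCF7 cells (Homo sapiens) for cytotoxicity, read by CellTiter-Blue, with a stated time of 72 h; on this read-out lower numbers stand for stronger inhibition and higher numbers for weaker inhibition.

Compound 1 `C/C=C(\C)[C@H]1OC(=O)[C@@H](C)NC(=O)[C@H]([C@@H](C)CC)NC(=O)CN(C)C(=O)[C@@H](Cc2ccccc2)N(C)C(=O)[C@H](C)NC(=O)[C@@H](CC(C)C)OC(=O)/C(C)=C/C[C@H](O)[C@@H]1C` gives 0.22 nM in this assay. Compound 3 `C/C=C(\C)[C@H]1OC(=O)[C@@H](C)NC(=O)[C@H]([C@@H](C)CC)NC(=O)CN(C)C(=O)[C@@H](Cc2ccc(Cl)cc2)N(C)C(=O)[C@H](C)NC(=O)[C@@H](CC(C)C)OC(=O)/C(C)=C/C[C@H](O)[C@@H]1C` gives 0.003 nM; it differs from compound 1 in one place only, (chloro in place of hydrogen on an aromatic carbon), and the step that this change made is a 73-fold lower number from compound 1 to compound 3 (1.87 log units; beyond the scatter). Compound 2 `C/C=C(\C)[C@@H](O)[C@@H](C)[C@@H]1C/C=C(\C)C(=O)O[C@H](CC(C)C)C(=O)N[C@@H](C)C(=O)N(C)[C@H](Cc2ccccc2)C(=O)N(C)CC(=O)N[C@@H]([C@@H](C)CC)C(=O)N[C@H](C)C(=O)O1` gives 0.29 nM; its core is built from the same atoms as the core of compound 1, joined differently, and the difference between the two cores is not broken down here. The values of compound 2 and compound 1 lie within the scatter of each other, so no order between them is read.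

Compound 4 `C/C=C(\C)[C@@H](O)[C@@H](C)[C@@H]1C/C=C(\C)C(=O)O[C@H](CC(C)C)C(=O)N[C@@H](C)C(=O)N(C)[C@H](Cc2ccc(Cl)cc2)C(=O)N(C)CC(=O)N[C@@H]([C@@H](C)CC)C(=O)N[C@H](C)C(=O)O1` has not yet been measured in this assay. Against compound 2 it carries chloro in place of hydrogen on an aromatic carbon, and the place of the change is described in the same words as the change from compound 1 to compound 3, so it is taken as the same change on the other core. For the measured compounds named here, the one precedent for the change is the single step from compound 1 to compound 3, which was large, and nothing in the data tells whether a differently joined core carries the change over in full. Going by the values given here, the expectation for compound 4 is therefore a step of a 29-fold lower number from compound 2 to compound 4 (1.46 log units; beyond the scatter), somewhat smaller than a 73-fold lower number from compound 1 to compound 3 (1.87 log units; beyond the scatter), to allow for the core difference and for the single precedent. On that basis compound 4 is expected to give about 0.01 nM in this assay, with a plausible range from 0.002 nM to 0.06 nM.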

Compound 4, half-maximal inhibitory concentration: 0.025 nM
Estimate against measurement, compound 4: 2.5-fold (0.40 log units) below; low and high end bracket the measured number.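

In this assay chloro in place of hydrogen on an aromatic carbon gives a 12-fold lower number from compound 2 to compound 4 (1.06 log units; beyond the scatter) on the core of compound 2, so the change goes the same way on both cores and the step is large on each. The size of the step does not carry over in full, and the gap between the two steps is beyond what repeated measurements would explain: the same change on two cores in this assay, a 73-fold lower number (1.87 log units; beyond the scatter) from compound 1 to compound 3 and a 12-fold lower number (1.06 log units; beyond the scatter) from compound 2 to compound 4, 6.3-fold (0.80 log units) apart, beyond the scatter of two such steps. This rests on a single pair for each core, so it shows that the core of compound 1 and the core of compound 2 can take this change to different extents, but it does not show what in the two cores sets the gap, or whether any other change would show a gap of the same kind.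

The compounds shown leave open whether fluoro, bromo, methoxy or an amine in place of that same hydrogen would give large steps on both cores, and whether those steps would also differ from one core to the other. They also leave open whether chloro placed elsewhere on the six-membered aromatic ring would behave as the 4-chlorobenzyl compounds do.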